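The source may hold more compounds than are shown below. What is called first, only, known or untested is meant among the compounds shown, and "the series" means these compounds.

Measured so far in a functional assay on A549 cells (Homo sapiens) for antiproliferative activity, read by XTT assay, with a stated time of 72 h; on this read-out higher numbers stand for weaker inhibition and lower numbers for stronger inhibition:
Compound 1, `COc1ccc(-c2cc3ccccc3nc2/C=C/C(=O)c2ccccc2)cc1`: 7410 nM
Compound 2, `COc1ccc(C(=O)/C=C/c2nc3ccccc3cc2-c2ccc(OC)cc2)cc1`: 8500 nM
Compound 3, `COc1ccc(-c2cc3ccccc3nc2/C=C/C(=O)c2c(OC)cccc2OC)cc1`: 7410 nM

Compound 3 sits level with compound 1, the pair together giving the lowest numbers of the three; compound 2 lies within the scatter of both. Compound 4, `COc1ccc(-c2cc3ccccc3nc2/C=C/C(=O)c2ccc(OC)c(OC)c2)cc1`, differs from compound 3 as follows: 3,4-dimethoxyphenyl in place of 2,6-dimethoxyphenyl on a carbonyl carbon. Among the measured compounds shown here, two measured steps concern the same carbonyl carbon: no change at the digits printed from compound 1 to compound 3 (within the scatter) and a 1.1-fold lower number from compound 2 to compound 3 (0.06 log units; within the scatter). Neither moved this assay beyond the scatter, and a 1.1-fold higher number from compound 1 to compound 2 (0.06 log units; within the scatter) likewise stayed within it. With every measured step flat, the expected step is a 1.0-fold higher number from compound 3 to compound 4 (0.01 log units; within the scatter), meaning none beyond the scatter. Compound 4 is therefore expected at about 7500 nM, with a range from 3500 nM to 16000 nM.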

Compound 4, half-maximal inhibitory concentration: 8860 nM
For compound 4 the middle estimate is 1.2-fold (0.07 log units) below the measured one, and the stated range covers the measured number.
By their numbers in this assay, from the lowest: compounds 1, 3, 2 and 4 (each within the scatter of the next).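

In this assay, rearranging the two methoxy groups into 3,4-dimethoxyphenyl on the carbonyl carbon gives a 1.2-fold higher number from compound 3 to compound 4 (0.08 log units; within the scatter), so their placement on this ring does not separate the compounds. Neither of the other comparisons at this place separates them: a 1.0-fold higher number from compound 2 to compound 4 (0.02 log units; within the scatter), and a 1.2-fold higher number from compound 1 to compound 4 (0.08 log units; within the scatter), so phenyl and all three methoxy-bearing rings remain indistinguishable here. No supporting data explain this flat read-out.

From the compounds shown here alone, whether an amine or a carboxylic acid on this ring would move the number beyond the scatter remains open. So does the effect of replacing the 4-methoxyphenyl group on the shared core.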